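Cytotoxicity notes on four compounds sharing one core

A few compounds are considered here, and "the series" means these few. Any claim that something is new, unique, unknown or untested is made for them only; others in the source may bear on it.

Measured compounds:
compound 1, `CC1(CN)CCN(c2cc3c(cc2F)c(=O)c(C(=O)O)cn3C2CC2)C1` — 23 ug/mL
compound 2, `CC1(CN)CCN(c2c(F)cc3c(=O)c(C(=O)O)cn(C4CC4)c3c2F)C1` — 8 ug/mL
compound 3, `CC1CN(c2cc3c(cc2F)c(=O)c(C(=O)O)cn3C2CC2)CC(C)N1` — > 500 ug/mL; this is a limit of the assay, not a number

All values come from a functional assay on V79 cells (Cricetulus griseus) for cytotoxicity, read by colony formation; a lower number here means a stronger inhibitor, a higher number a weaker inhibitor. Compound 1 and compound 2 differ by fluoro in place of hydrogen on an aromatic carbon; this change gives a 2.9-fold lower number from compound 1 to compound 2 (0.46 log units; beyond the scatter). Compound 1 and compound 3 have the same atoms joined differently, (3,5-dimethylpiperazin-1-yl in place of 3-(aminomethyl)-3-methylpyrrolidin-1-yl on an aromatic carbon); this change gives an at least 21-fold higher number from compound 1 to compound 3 (1.33 log units; beyond the scatter). The step to compound 3 is open at its upper end, since compound 3 sits at the limit of > 500 ug/mL in this assay, at which 1 of the 3 values shown sits.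

Compound 4, `CC1CN(c2c(F)cc3c(=O)c(C(=O)O)cn(C4CC4)c3c2F)CC(C)N1`, has not yet been measured in this assay. It differs from compound 3 by fluoro in place of hydrogen on an aromatic carbon. Among the measured compounds shown here, this is the same kind of change as the one from compound 1 to compound 2, here placed ortho to a 3,5-dimethylpiperazin-1-yl group rather than ortho to a 3-(aminomethyl)-3-methylpyrrolidin-1-yl group; the rest of the surroundings read the same.

The step from compound 3 to compound 4 in this assay is expected to be an at least 1.4-fold lower number from compound 3 to compound 4 (0.15 log units; that floor lies within the scatter), resting on the earlier step of a 2.9-fold lower number from compound 1 to compound 2 (0.46 log units; beyond the scatter). Compound 3 gives only a limit, > 500 ug/mL, which leaves the starting point undefined. Compound 4 is estimated at about 350 ug/mL, most likely between 150 ug/mL and 1000 ug/mL, with a fair chance that it too is reported only as a limit.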

Compound 4, half-maximal inhibitory concentration: 150 ug/mL
Estimate against measurement, compound 4: 2.3-fold (0.37 log units) above, and the stated range covers the measured number.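

In this assay, fluoro in place of hydrogen on an aromatic carbon, ortho to a 3,5-dimethylpiperazin-1-yl group, gives an at least 3.3-fold lower number from compound 3 to compound 4 (0.52 log units; beyond the scatter), which points the same way as the step on the core bearing the 3-(aminomethyl)-3-methylpyrrolidin-1-yl group: the same change on two cores in this assay, a 2.9-fold lower number (0.46 log units; beyond the scatter) from compound 1 to compound 2 and an at least 3.3-fold lower number (0.52 log units; beyond the scatter) from compound 3 to compound 4; the limit leaves it open whether they differ

The exchange of the two amine groups, made here on the core of compound 2, gives a 19-fold higher number from compound 2 to compound 4 (1.27 log units; beyond the scatter), again in the same direction as on the core of compound 1: the same change on two cores in this assay, an at least 21-fold higher number (1.33 log units; beyond the scatter) from compound 1 to compound 3 and a 19-fold higher number (1.27 log units; beyond the scatter) from compound 2 to compound 4; the limit leaves it open whether they differ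

Compound 3 is reported as > 500 ug/mL, a limit of the assay and not a number, so both changes are shown to carry over in direction across these two pairs, while it is not shown that their sizes match.

The compounds shown leave open whether the fluoro step holds with other groups on that carbon, such as an unsubstituted piperazin-1-yl group or a longer chain ending in an amine. They also leave open whether chloro or methoxy in place of that fluoro would move the number in this assay in the same direction, and which part of the 3,5-dimethylpiperazin-1-yl group accounts for the step away from the 3-(aminomethyl)-3-methylpyrrolidin-1-yl group.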